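The source may hold more compounds than are shown below. What is called first, only, known or untested is meant among the compounds shown, and "the series" means these compounds.

Compound 1 `CN1CCCN(c2cncc(-c3cc(CCO)no3)c2)CC1` and compound 2 `COCC[C@@H]1C[C@H]1c1cncc(N2CCCNCC2)c1` share a core that carries a seven-membered ring with two nitrogens, and they have been looked at for their largest response in an assay on SH-EP1 cells for antagonist activity at Neuronal acetylcholine receptor; alpha4/beta2 (Homo sapiens), read by rubidium efflux, with stated times of 10 min and 5 min; on this read-out lower numbers stand for smaller maximal responses and higher numbers for larger maximal responses. For compound 1 the outcome in this assay is "not determined" (no result reported), so there is no number on which compound 1 can be placed. In this assay, within the data shown here, compound 2 gives 79%, the only value available. Compound 3 `OCCc1cc(-c2cncc(N3CCCNCC3)c2)on1` is derived from compound 1 by one change, (hydrogen in place of methyl on an amine nitrogen in a ring), and it is still to be measured in this assay. Since compound 1 has no value, the size of the step to compound 3 cannot be set against a starting point, and no expected direction in this assay can be stated for that step; the expectation rests on compound 2 alone, which shares with compound 3 the hydrogen on the amine nitrogen in the ring. On that basis compound 3 is estimated to give a largest response of 75%, with a range from 45% to 100%.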

Compound 3, largest response reached (reported as efficacy), in percent of the reference or control that the assay uses: 68%
Compound 3: the middle estimate sits 7 percentage points above what was measured; the range from low to high includes it.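

In this assay, among these compounds, compound 1 gives "not determined" (no result reported), so no step from compound 1 to compound 3 can be read. The compounds shown leave open what hydrogen in place of methyl on the amine nitrogen in the ring does to the largest response. No evidence bearing on the result of compound 3 is available.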